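This account rests on a few compounds, and the source may have more. Where it says the series, first, only, none or still open, it means among the compounds named here.

Measured compounds:
compound 1, `COC1=C(C)C(=O)/C(=C(O)/C=C/c2ccccc2C)C(=O)C1(C)C`: 4.1 ug/mL
compound 2, `COC1=C(C)C(=O)/C(=C(O)/C=C/c2c(C)cccc2C)C(=O)C1(C)C`: 7.1 ug/mL
compound 3, `CCC1=C(OC)C(CC)(CC)C(=O)C(C(=O)/C=C/c2ccccc2)=C1O`: 2.8 ug/mL

In a functional assay on KB cells (Homo sapiens) for cytotoxicity (on this read-out lower numbers stand for an effect already at smaller amounts and higher numbers for an effect only at larger amounts of compound), compound 3 gives the lowest number of the three; its nearest neighbour is compound 1, and that gap is within the scatter, while the gap to compound 2 is beyond it. The difference between the core of compound 1 and the core of compound 3 is not broken down here. Between compound 1 and compound 2 the change is methyl in place of hydrogen on an aromatic carbon, and it gave a 1.7-fold higher number from compound 1 to compound 2 (0.24 log units; within the scatter). Compound 4, `CCC1=C(OC)C(CC)(CC)C(=O)C(C(=O)/C=C/c2ccc(C)cc2)=C1O`, is not yet measured in this assay. It differs from compound 3 by methyl in place of hydrogen on an aromatic carbon, the same kind of change as from compound 1 to compound 2, but here the methyl sits para to a large group rather than ortho to a large group and meta to a methyl group. For the measured compounds named here, only one earlier instance of this kind of change is known, and it stayed within the scatter. Going by the values given here, the step expected here is correspondingly small, a 1.3-fold higher number from compound 3 to compound 4 (0.11 log units; within the scatter), and rests on the single earlier step, a 1.7-fold higher number from compound 1 to compound 2 (0.24 log units; within the scatter). For compound 4 the expected value in this assay is 3.6 ug/mL, estimated to lie between 1.8 ug/mL and 7.5 ug/mL.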

Compound 4, concentration for half-maximal effect: 3 ug/mL
Estimate against measurement, compound 4: 1.2-fold (0.08 log units) above, within the range that was stated.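

In this assay, methyl in place of hydrogen on an aromatic carbon, here para to a large group, gave a 1.1-fold higher number from compound 3 to compound 4 (0.03 log units; within the scatter). Set beside the earlier instance of this change, the step shows no detectable dependence on the core: the same change on two cores in this assay, a 1.7-fold higher number (0.24 log units; within the scatter) from compound 1 to compound 2 and a 1.1-fold higher number (0.03 log units; within the scatter) from compound 3 to compound 4, 1.6-fold (0.21 log units) apart, within the scatter of two such steps. For the compounds shown here, this does not establish that the change transfers generally: both steps are small, only two cores are covered, the methyl does not sit in the same place in the two pairs, and the data cannot separate an effect of the core from one of position or show whether a larger step would carry over.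

The compounds shown leave open whether a carboxylic acid or an amine in place of the methyl on the aromatic ring would move the number beyond the scatter on either core. Also open, from the compounds shown here alone, is what a longer chain in place of the ethyl groups on the core of compound 3 would do.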